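Swapping the Bromophenyl for a Difluorophenyl

This account rests on a few compounds, and the source may have more. Where it says the series, first, only, none or still open, it means among the compounds named here.

Compound 1 `O=C1O[C@H]([C@@H](O)Cn2cc(-c3ccc(Br)cc3)nn2)C(OCc2ccccc2)=C1OCc1ccccc1` is the starting point. In a functional assay on HepG2 cells (Homo sapiens) for antiproliferative activity, read by MTT assay, with a stated time of 72 h (a lower number here means a stronger inhibitor, a higher number a weaker inhibitor), compound 1 gives 5070 nM, which is the lowest of the two numbers shown. Its closest neighbour, compound 3 `CCCCCCCCCCc1cn(C[C@H](O)[C@H]2OC(=O)C(OCc3ccccc3)=C2OCc2ccccc2)nn1`, gives 12200 nM, and the change a 2.4-fold higher number from compound 1 to compound 3 (0.38 log units; beyond the scatter). Compound 2 `O=C1O/C(=C\Cn2cc(-c3cc(C(F)(F)F)cc(C(F)(F)F)c3)nn2)C(OCc2ccccc2)=C1OCc1ccccc1`, which carries a different core, gives > 100000 nM, which is the limit of this assay, (the limit of > 100000 nM in this assay, at which 1 of the 3 values shown sits), and so no number.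

Compound 4 `O=C1O[C@H]([C@@H](O)Cn2cc(-c3cc(F)cc(F)c3)nn2)C(OCc2ccccc2)=C1OCc1ccccc1` differs from compound 1 in one place: 3,5-difluorophenyl in place of 4-bromophenyl on an aromatic carbon. Among the compounds with values here, the only measured step at this position is the one from compound 1 to compound 3, where an aromatic ring gave way to a chain and the number rose modestly. Here one aromatic ring replaces another of similar size, so a step of at most that scale is expected, in either direction or none beyond the scatter. For compound 4 the estimate in this assay is 6000 nM, with a range from 2500 nM to 15000 nM, meaning an expected step of a 1.2-fold higher number from compound 1 to compound 4 (0.07 log units; within the scatter).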

Compound 4, half-maximal inhibitory concentration: 11600 nM
Compound 4: the middle estimate sits 1.9-fold (0.29 log units) below what was measured; the measured number falls inside the stated range.
By their numbers in this assay, from the lowest: compound 1; then compounds 4 and 3 (each within the scatter of the next). At a limit, above all of these: compound 2.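

In this assay, the 4-bromophenyl of compound 1 proves not to be freely exchangeable for another aromatic ring, since 3,5-difluorophenyl gives a 2.3-fold higher number from compound 1 to compound 4 (0.36 log units; beyond the scatter) even though both groups are a single six-membered aromatic ring of carbon only. That replacement also lands level with the decyl chain, with a 1.1-fold lower number from compound 3 to compound 4 (0.02 log units; within the scatter), so at this position an aromatic ring alone does not keep the number as low as in compound 1. Nothing measured here gives a property that accounts for the gap between the two rings.

Going by these compounds, it remains open whether the bromine itself matters, which a 4-chlorophenyl, a 4-methylphenyl or an unsubstituted phenyl ring could test. A phenyl ring carrying an amine or a carboxylic acid, or a chain shorter than decyl, would also show how much this position tolerates.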